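The source may hold more compounds than are shown below. What is called first, only, known or untested is meant among the compounds shown, and "the series" means these compounds.

Two compounds share the same core. In a functional assay on RXF 393 cells (Homo sapiens) for inhibition, read by sulforhodamine B assay, with a stated time of 48 h (on this read-out lower numbers stand for higher toxicity in this test and higher numbers for lower toxicity in this test), compound 1 `COc1ccc(-c2cc(/C=C/C(=O)c3ccc(N)cc3)[nH]n2)cc1` gives 15000 nM, and in this assay compound 2 `COc1cc(-c2cc(/C=C/C(=O)c3ccc(N)cc3)[nH]n2)cc(OC)c1OC` gives 7790 nM. Among the compounds with values here, compound 2 thus stands at one of only two numbers, and the gap between compound 2 and compound 1 lies within the scatter, so the two cannot be told apart on these data. Compound 3 `COc1ccc(-c2cc(/C=C/C(=O)c3ccc(N)cc3)[nH]n2)cc1OC` is reached from compound 2 by a single change: hydrogen in place of methoxy on an aromatic carbon. Within the data shown here, no measured pair shows this exact step, so only the two numbers of compound 1 and compound 2 give any guide, and they point to a difference within the scatter. The step from compound 2 to compound 3 is therefore expected to be small, a 1.3-fold higher number from compound 2 to compound 3 (0.11 log units; within the scatter), in no firm direction. Compound 3 is expected to give about 10000 nM in this assay, within a range from 4000 nM to 25000 nM.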

Compound 3, concentration lethal to 50% of the cells: 15900 nM
Compound 3: middle estimate off by 1.6-fold (0.20 log units), on the low side; the measured number falls inside the stated range.
By their numbers in this assay, from the lowest: compounds 2, 1 and 3 (each within the scatter of the next, the first and the last beyond it).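

Removing the methoxy group that sits ortho to a methoxy group and meta to a large group gives a 2.0-fold higher number from compound 2 to compound 3 (0.31 log units; beyond the scatter) in this assay, the first single-place change shown here to reach beyond the scatter, though only modestly. Placing a methoxy group on an aromatic carbon of compound 1 gives a 1.1-fold higher number from compound 1 to compound 3 (0.03 log units; within the scatter) and leaves the two compounds indistinguishable, so a methoxy change on this ring does not always register in this read-out. The compounds shown offer no explanation for this difference between the two steps.

On these data alone, what a hydroxyl group or a chlorine atom would give on the carbon that differs between compound 2 and compound 3 remains open. Also open, as far as these compounds go, is whether any group there could move the number further than this modest step.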